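This account rests on a few compounds, and the source may have more. Where it says the series, first, only, none or still open, it means among the compounds named here.

Measured so far:
- compound 1, `O=C(O)c1ccc2c(c1)CC(CNS(=O)(=O)c1ccc(Cl)cc1)C2`: 1320 nM
- compound 2, `O=C(O)c1ccc2c(c1)CC(CCNS(=O)(=O)c1ccc(Cl)cc1)C2`: 7760 nM

Both compounds were tested in a functional assay for antagonist activity at thromboxane A2 receptor (Homo sapiens); a higher number here means a weaker inhibitor, a lower number a stronger inhibitor. Compound 1 gives 1320 nM and compound 2 gives 7760 nM, so compound 2 carries the higher of the two numbers, and the gap between compound 2 and compound 1 lies beyond the usual scatter of this assay. The two compounds share the same core and the same sulfonamide arm; they differ in the length of the linker to the sulfonamide nitrogen, with compound 2 carrying the longer chain.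

Compound 3, `O=C(O)Cc1ccc2c(c1)CC(CCNS(=O)(=O)c1ccc(Cl)cc1)C2`, has not been measured. It differs from compound 2 in one place: carboxymethyl in place of carboxy on an aromatic carbon. The carboxy group on the aromatic ring of compound 2 is replaced by carboxymethyl, so the acid is moved out by one carbon while the rest of the molecule, including the longer linker of compound 2, is unchanged.

Among the compounds with values here, no measured pair in this set shows what this change does. With only a single point of reference in compound 2 at 7760 nM, the expectation is a shift of a 1.3-fold higher number from compound 2 to compound 3 (0.11 log units; within the scatter), most likely toward a somewhat higher number, but a result within the scatter would not be surprising. Compound 3 is therefore estimated at 10000 nM in this assay, with a range of 2500 nM to 40000 nM.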

Compound 3, half-maximal inhibitory concentration: 1480 nM
Compound 3: middle estimate off by 6.8-fold (0.83 log units), on the high side, outside the stated range (below it).
By their numbers in this assay, from the lowest: compounds 1 and 3 (each within the scatter of the next); then compound 2.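

In this assay, carboxymethyl in place of carboxy on an aromatic carbon gives a 5.2-fold lower number from compound 2 to compound 3 (0.72 log units; beyond the scatter), a change beyond the scatter toward stronger inhibition with the longer linker of compound 2 held constant. Within the data shown here, this is the first single-place step, and it shows that the group on this aromatic carbon, part of the fused system, has a measurable effect on the read-out: the acid-bearing substituent here is not a fixed feature, and carboxy is not the better of the two groups on this linker. The size of the step is a result for this one linker only, and no measurement at hand bears on why the longer acid-bearing group gives the lower number.

Whether carboxymethyl gives a similar step on the shorter linker of compound 1 remains open, as that pairing lies outside the compounds shown. Also open, from the compounds shown here alone, is how far the trend at this aromatic carbon extends, for instance to a longer chain ending in a carboxylic acid, such as carboxyethyl, or to an amide in place of the acid.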